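The source may hold more compounds than are shown below. What is called first, only, known or untested is meant among the compounds shown, and "the series" means these compounds.

Compound 1 `Cc1cccc(CN2CCC3(CC2)OCCc2sccc23)c1` carries a 3-methylphenyl on a saturated chain carbon bound to an amine nitrogen in a ring. In an ADME assay on microsomes from liver (Mus musculus) for metabolic stability, read by LC-MS, using NADPH, with a stated time of 30 min, tested at 0.5 uM (a lower number here means slower removal, a higher number faster removal of the compound), compound 1 gives > 30 mL/min/g, which is a limit of the assay and not a number. Compound 2 `Cc1ccc(CN2CCC3(CC2)OCCc2sccc23)cc1C` differs from compound 1 by a methyl in place of hydrogen on an aromatic carbon. In this assay compound 2 gives > 30 mL/min/g, again a limit. The step that the two limits leave unreadable from compound 1 to compound 2 cannot be read because both measurements sit at the limit of > 30 mL/min/g in this assay, at which 2 of the 2 values shown sit. Compound 3 `Cc1ccc(CN2CCC3(CC2)OCCc2sccc23)[nH]1` differs from compound 1 by 5-methyl-1H-pyrrol-2-yl in place of 3-methylphenyl on a saturated chain carbon bound to an amine nitrogen in a ring. Within the data shown here, no measured step bears on this change, and the one step on record gives no size to lean on. The step that the limit leaves unreadable from compound 1 to compound 3 is therefore estimated from the limit alone. Compound 3 is expected to give 40 mL/min/g in this assay, within a range from 20 mL/min/g to 100 mL/min/g.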

Compound 3, intrinsic clearance in a liver preparation (reported as CLH), per the amount of preparation that the assay uses: 28.7 mL/min/g
The estimate for compound 3 lay 1.4-fold (0.14 log units) above the measured number; the measured number falls inside the stated range.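

With 5-methyl-1H-pyrrol-2-yl on a saturated chain carbon bound to an amine nitrogen in a ring, compound 3 is the only compound shown that gives a number in this assay, 28.7 mL/min/g. The change gives an at least 1.0-fold lower number from compound 1 to compound 3 (0.01 log units; that floor lies within the scatter), so the replacement of the 3-methylphenyl, with a five-membered aromatic ring and a hydrogen-bond donor entering, brings the reading within the range of the assay but shows no change beyond the scatter. The true size of the step stays unknown because compound 1 sits at a limit of the assay: the limit of > 30 mL/min/g in this assay, at which 2 of the 3 values shown sit.

The compounds shown leave open whether the methyl on the 5-methyl-1H-pyrrol-2-yl or the ring nitrogen matters for this reading. They also leave open how an amine, a carboxylic acid or a longer chain at this place would read in this assay.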